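Fluorine Added to a Shared Amide-Linked Core

The compounds below may be only part of what the source reports. "The series", "measured", "known", "first", "only" and "open" are said of these compounds alone.

Three measured compounds share one core and differ only in the group on the carbonyl carbon of the amide: compound 1 `C=CC(=O)Nc1cccc(-c2nc3ccccc3s2)c1` carries a vinyl group, compound 2 `CN(C)CCC(=O)Nc1cccc(-c2nc3ccccc3s2)c1` a 2-(dimethylamino)ethyl group, and compound 3 `O=C(Nc1cccc(-c2nc3ccccc3s2)c1)c1cnccc1Cl` a 4-chloropyridin-3-yl group. In an ADME assay on HEK293 cells (Homo sapiens) for inhibition, with a stated time of 72 h (on this read-out higher numbers stand for an effect only at larger amounts of compound and lower numbers for an effect already at smaller amounts), compound 1 reaches only the limit of the assay, > 25000 nM. In this assay compound 2 likewise stops at a limit, > 25000 nM. Compound 3 also gives a limit in this assay, > 25000 nM. Because of the limit of > 25000 nM in this assay, at which 3 of the 3 values shown sit, none of the comparisons between these compounds can be read: a step that the two limits leave unreadable from compound 1 to compound 2, a step that the two limits leave unreadable from compound 1 to compound 3 and a step that the two limits leave unreadable from compound 2 to compound 3 all remain of unknown size.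

Compound 4 `O=C(Nc1ccc(F)c(-c2nc3ccccc3s2)c1)c1cnccc1Cl` differs from compound 3 in one place: fluoro in place of hydrogen on an aromatic carbon, on an aromatic carbon of a six-membered aromatic ring of carbon only, ortho to a group of 9 heavy atoms and para to a large group. Within the data shown here, no measured step touches this position, and the steps that exist are unreadable, so there is no evidence for a change in either direction beyond the scatter. Compound 4 is therefore expected to sit at the limit as well, an estimated 40000 nM with a range of 15000 nM to 100000 nM, and the expected step that the limit leaves unreadable from compound 3 to compound 4 means no readable change.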

Compound 4, half-maximal effective concentration: > 25000 nM
Compound 4 ended at the assay's limit; the forecaster's own chance of this, stated with the estimate: 85%; the middle value lies beyond the limit too.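

No step can be read from compound 3 to compound 4, because the fluoro compound stops at the assay's limit just as its parent does: the limit of > 25000 nM in this assay, at which 4 of the 4 values shown sit.

The compounds shown leave open whether any group on the carbonyl carbon or on the aromatic carbon carrying fluoro in compound 4 can shift this read-out at all, and in which direction.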